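Replacing 4-chlorophenyl with 3-nitrophenyl on the shared core

A few compounds are considered here, and "the series" means these few. Any claim that something is new, unique, unknown or untested is made for them only; others in the source may bear on it.

In a toxicity assay (J774.1 cells) for cytotoxicity, with Mus musculus as the target, read by resazurin assay, with a stated time of 24 h (a lower number here means a stronger inhibitor, a higher number a weaker inhibitor), compound 1 (`CC(C)Nc1ccc(CS(=O)(=O)N2CCCCC2C(=O)OCCCc2cccnc2)cc1`) gives 44300 nM and compound 2 (`O=C(OCCCc1cccnc1)[C@@H]1CCCCN1S(=O)(=O)Cc1ccc(Cl)cc1`) gives 33600 nM so that compound 2 stands within the scatter of compound 1. Compound 3 (`O=C(OCCCc1cccnc1)[C@@H]1CCCCN1S(=O)(=O)Cc1cccc([N+](=O)[O-])c1`), not yet measured, differs from compound 2 (3-nitrophenyl in place of 4-chlorophenyl on a saturated chain carbon bound to a sulfonyl sulfur) by having 3-nitrophenyl in place of 4-chlorophenyl on a saturated chain carbon bound to a sulfonyl sulfur. Among the compounds with values here, no measured pair isolates a single change, so the expectation rests only on those two close values, and no step beyond the scatter is expected in this assay here. The expected change is a 1.1-fold lower number from compound 2 to compound 3 (0.02 log units; within the scatter) and stays within the scatter. Compound 3 is estimated at 32000 nM (expected range 14000 nM to 70000 nM).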

Compound 3, half-maximal inhibitory concentration: 48200 nM
For compound 3 the middle estimate is 1.5-fold (0.18 log units) below the measured one; measured number inside the range.
By their numbers in this assay, from the lowest: compounds 2, 1 and 3 (each within the scatter of the next).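

In this assay, within the data shown here, 3-nitrophenyl in place of 4-chlorophenyl on a saturated chain carbon bound to a sulfonyl sulfur gives a 1.4-fold higher number from compound 2 to compound 3 (0.16 log units; within the scatter), the first step here that isolates a single change. At this position, the two aryl groups cannot be told apart in this assay, even though only the 3-nitrophenyl group carries hydrogen-bond acceptors. No measurement is available that explains this result. From the compounds shown here alone, whether an amine or a carboxylic acid at the same position would give a step beyond the scatter remains open.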